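A few compounds are considered here, and "the series" means these few. Any claim that something is new, unique, unknown or untested is made for them only; others in the source may bear on it.

Compound 3 `CNc1nc2cc(Cl)c(Cl)cc2n1COC(CO)CO` in a functional assay on KB cells (Homo sapiens) for inhibition (a lower number here means a stronger inhibitor, a higher number a weaker inhibitor), gives > 100000 nM, which is a limit of the assay and not a number. Compound 1 `OCC(CO)OCn1c(Cl)nc2cc(Cl)c(Cl)cc21` in this assay gives > 100000 nM, likewise a limit. Compound 2 `Nc1nc2cc(Cl)c(Cl)cc2n1COC(CO)CO` in this assay gives > 100000 nM, again a limit. Because of the limit of > 100000 nM in this assay, at which 3 of the 3 values shown sit, the three steps among them, a step that the two limits leave unreadable from compound 1 to compound 2, a step that the two limits leave unreadable from compound 1 to compound 3 and a step that the two limits leave unreadable from compound 2 to compound 3, cannot be sized. Compound 4 `CN(C)c1nc2cc(Cl)c(Cl)cc2n1COC(CO)CO` differs from compound 3 by methyl in place of hydrogen on a nitrogen on an aromatic ring. Among the measured compounds shown here, the single measured step of the same kind, a step that the two limits leave unreadable from compound 2 to compound 3, gives no readable size, so no direction can be taken from it. Compound 4 is therefore expected to show a step that the limit leaves unreadable from compound 3 to compound 4 in this assay, most likely again returning a limit. The estimate for compound 4 is 150000 nM, in the range 50000 nM to 500000 nM.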

Compound 4, half-maximal inhibitory concentration: > 100000 nM
Compound 4: only a limit was reported (the forecaster's own chance of this, stated with the estimate: 85%); the middle value lies beyond the limit too.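

No step can be read among compound 1, compound 2, compound 3 and compound 4, because each value is a limit and not a number: the limit of > 100000 nM in this assay, at which 4 of the 4 values shown sit.

In this assay the compounds shown leave open how chloro, amino, methylamino and dimethylamino rank against one another.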